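This account rests on a few compounds, and the source may have more. Where it says the series, first, only, none or still open, it means among the compounds named here.

Compound 1 `COc1ccc(C2=NN(C(=O)c3cccnc3)C(c3cn(C)c4ccc(Br)cc34)C2)cc1OC` gives 2450 nM in a functional assay on HepG2 cells (Homo sapiens) for inhibition, read by MTT assay, with a stated time of 48 h; a lower number here means a stronger inhibitor of growth, a higher number a weaker inhibitor of growth. Compound 2 `COc1cc(C2=NN(C(=O)c3cccnc3)C(c3cn(C)c4ccc(Br)cc34)C2)cc(OC)c1OC` gives only the assay limit > 10000 nM in this assay. Compound 3 `COc1ccc2c(c1)c(C1CC(c3ccccc3)=NN1C(=O)c1cccnc1)cn2C` gives 5110 nM in this assay.

Going from compound 1 to compound 2 the change is methoxy in place of hydrogen on an aromatic carbon, and it brought an at least 4.0-fold higher number from compound 1 to compound 2 (0.61 log units; beyond the scatter), because the limit of > 10000 nM in this assay, at which 1 of the 3 values shown sits, caps what can be read. Compound 4 `COc1cccc(C2=NN(C(=O)c3cccnc3)C(c3cn(C)c4ccc(OC)cc34)C2)c1` is not yet measured; it differs from compound 3 by methoxy in place of hydrogen on an aromatic carbon, the same kind of change, but here the place is only meta to a large group, whereas in compound 1 it was also ortho to a methoxy group and meta to a methoxy group. The difference between the cores of compound 3 and compound 1 is not broken down here. For compound 4 in this assay the expected step is a 1.8-fold higher number from compound 3 to compound 4 (0.25 log units; within the scatter), resting on an at least 4.0-fold higher number from compound 1 to compound 2 (0.61 log units; beyond the scatter), while allowing that the surroundings differ. Compound 4 is therefore estimated at 9000 nM, with a range of 3500 nM to 20000 nM.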

Compound 4, concentration for 50% growth inhibition: 910 nM
Compound 4: the middle estimate sits 9.9-fold (1.00 log units) above what was measured; the measured number lies below the stated range.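

Methoxy in place of hydrogen, here phenyl to 3-methoxyphenyl, gave a 5.6-fold lower number from compound 3 to compound 4 (0.75 log units; beyond the scatter). The same kind of change therefore did not carry over from one core to the other in this assay: the same change on two cores in this assay, an at least 4.0-fold higher number (0.61 log units; beyond the scatter) from compound 1 to compound 2 and a 5.6-fold lower number (0.75 log units; beyond the scatter) from compound 3 to compound 4, at least 22-fold (1.36 log units) apart, beyond the scatter of two such steps. This does not show what causes the difference, as the two pairs differ both in their core and in the surroundings of the new methoxy group, and these cannot be separated here.

As far as these compounds go, compound 2 gives > 10000 nM, which is a limit of the assay and not a number, so its true value remains open. Also open, from the compounds shown here alone, is whether an amine or a carboxylic acid in place of the methoxy group on compound 4 would keep its growth inhibition.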